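The compounds below may be only part of what the source reports. "The series", "measured", "known", "first", "only" and "open" are said of these compounds alone.

Measured so far in an ADME assay on MT4 cells (Homo sapiens) for cytotoxicity, read by MTT assay; a higher number here means that more compound is tolerated, a lower number that less compound is tolerated:
- Compound 1 `Cc1cccc(C(=O)N(C(=S)OCCN2C(=O)c3ccccc3C2=O)c2ccc(Cl)cc2)c1`: 58000 nM
- Compound 2 `Cc1ccc(C(=O)N(C(=S)OCCN2C(=O)c3ccccc3C2=O)c2ccc(Cl)cc2)cc1`: > 100000 nM (a limit)
- Compound 3 `O=C1c2ccccc2C(=O)N1CCOC(=S)N(C(=O)c1ccc([N+](=O)[O-])cc1)c1ccc(Cl)cc1`: > 100000 nM (a limit)

Compound 3 stands at > 100000 nM, which is a limit of the assay and not a number. It therefore shares (the limit of > 100000 nM in this assay, at which 2 of the 3 values shown sit). Compound 4 `O=C1c2ccccc2C(=O)N1CCOC(=S)N(C(=O)c1ccc(F)cc1F)c1ccc(Cl)cc1` carries 2,4-difluorophenyl in place of 4-nitrophenyl on a carbonyl carbon.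

Earlier changes on that carbonyl carbon bear on this one. They gave an at least 1.7-fold higher number from compound 1 to compound 2 (0.23 log units; that floor lies within the scatter) and an at least 1.7-fold higher number from compound 1 to compound 3 (0.23 log units; that floor lies within the scatter). The remaining comparison gives a step that the two limits leave unreadable from compound 2 to compound 3. None of these steps is shown to lie beyond the scatter, so no clear step is expected in this assay, in either direction. Still, compound 1 at 58000 nM shows that this series can give a measured number, so a measured value remains possible. The expected change is an at least 1.1-fold lower number from compound 3 to compound 4 (0.04 log units; that floor lies within the scatter). The estimate for compound 4 is 90000 nM, with an expected range from 45000 nM to 180000 nM.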

Compound 4, half-maximal cytotoxic concentration: 52000 nM
Compound 4: the middle estimate sits 1.7-fold (0.24 log units) above what was measured, and the stated range covers the measured number.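

In this assay, 2,4-difluorophenyl on the carbonyl carbon gives a second measured number in this series, so a measured value at this position is no longer confined to 3-methylphenyl. Against the two limit compounds the change reads as an at least 1.9-fold lower number from compound 3 to compound 4 (0.28 log units; that floor lies within the scatter) and an at least 1.9-fold lower number from compound 2 to compound 4 (0.28 log units; that floor lies within the scatter), while against the other measured compound it reads as a 1.1-fold lower number from compound 1 to compound 4 (0.05 log units; within the scatter), so no step at this position is yet shown to lie beyond the scatter. The two floors rest on limits of the assay and not on numbers: the limit of > 100000 nM in this assay, at which 2 of the 4 values shown sit.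

On these data alone, it remains open how far compound 2 and compound 3 actually lie from the two measured compounds, and whether any group at this position gives a step beyond the scatter. Also open, as far as these compounds go, is how an amine or a carboxylic acid on this aromatic ring would read in this assay.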